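The source may hold more compounds than are shown below. What is called first, only, known or untested is meant among the compounds shown, and "the series" means these compounds.

Measured so far:
Compound 1, `O=C(Nc1ccc(N(CC2CC2)CC2CC2)cc1Cl)c1cc(Cl)ccc1O`: 12800 nM
Compound 2, `O=C(Nc1ccc(NCc2cc(Cl)cc(C(F)(F)F)c2)cc1Cl)c1cc(Cl)ccc1O`: 30900 nM

Of the compounds shown here, two sharing one core have been tested in an ADME assay on A549 cells (Homo sapiens) for cytotoxicity, read by resazurin assay, with a stated time of 48 h; on this read-out lower numbers stand for higher toxicity in this test and higher numbers for lower toxicity in this test. Compound 1 gives 12800 nM, the lower of the two numbers, so it is the more toxic of the pair in this test. Compound 2 gives 30900 nM; the gap between the two lies beyond the usual scatter of repeated measurements, so the difference is real.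

Compound 3, `O=C(Nc1ccc(NCc2cccnc2Cl)cc1Cl)c1cc(Cl)ccc1O`, has not yet been measured. It differs from compound 1 in one place: ((2-chloropyridin-3-yl)methyl)amino in place of bis(cyclopropylmethyl)amino on an aromatic carbon. The group that leaves holds two three-membered non-aromatic rings of carbon only and no hydrogen-bond donor; the one that enters brings a six-membered aromatic ring with one hetero atom and one hydrogen-bond donor. Among the compounds with values here, no measured pair shows this exact change, so its effect in this assay is uncertain. Since compound 2 gives 30900 nM, the higher of the two numbers, a modest shift toward lower toxicity seems plausible, and the step from compound 1 to compound 3 is expected to be a 1.6-fold higher number from compound 1 to compound 3 (0.19 log units; within the scatter). Compound 3 is therefore estimated at 20000 nM, with a likely range from 8000 nM to 50000 nM.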

Compound 3, half-maximal cytotoxic concentration: 101000 nM
For compound 3 the middle estimate is 5.1-fold (0.70 log units) below the measured one; the whole stated range lies below it.
By their numbers in this assay, from the lowest: compound 1; then compound 2; then compound 3.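

In this assay the swap of bis(cyclopropylmethyl)amino for ((2-chloropyridin-3-yl)methyl)amino, on the aromatic carbon para to a large group, gives a 7.9-fold higher number from compound 1 to compound 3 (0.90 log units; beyond the scatter) and so lower toxicity in this test. This shows that a change at this one place on the shared core can move the read-out well beyond the usual scatter. Both groups hold 9 heavy atoms, so the heavy-atom count of the group alone does not set the number in this pair, and nothing measured here explains the shift.

The swap changes several things at once: the two three-membered rings leave, while an aromatic ring, a chlorine and a hydrogen-bond donor enter, and these compounds cannot show which of these changes matters. A single cyclopropylmethylamino group, which keeps the amine hydrogen and one small ring, or a pyridin-3-ylmethylamino group without the chlorine, would help separate these contributions.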